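From Hydroxy to Methoxy at the Assay Limit

A few compounds are considered here, and "the series" means these few. Any claim that something is new, unique, unknown or untested is made for them only; others in the source may bear on it.

Measured in an ADME assay on RAW264.7 cells (Mus musculus) for cytotoxicity, read by MTT assay, with a stated time of 24 h, in the absence of a further agent; a higher number here means a weaker inhibitor, a lower number a stronger inhibitor; each value is a limit, not a number:
Compound 1 `Cc1noc(CC2OC(=O)c3ccccc32)n1`: > 40000 nM
Compound 2 `O=C1OC(Cc2nc(-c3ccc(-c4ccccc4)cc3)no2)c2ccccc21`: > 40000 nM
Compound 3 `COc1cc(OC)c2c(c1)C(C(O)c1ccc(O)cc1)OC2=O`: > 40000 nM

Compound 3 gives > 40000 nM, and this is a limit of this assay rather than a number. It has no separate standing in the set, for the three measured compounds share (the limit of > 40000 nM in this assay, at which 3 of the 3 values shown sit). Among the compounds with values here, no two of them differ in one place, so no measured step is available as a guide.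

Compound 4 `COc1ccc(C(O)C2OC(=O)c3c(OC)cc(OC)cc32)cc1` has not yet been measured. It differs from compound 3 by methyl in place of hydrogen on an oxygen on an aromatic ring: a methyl in place of hydrogen on an oxygen on an aromatic ring, which turns hydroxy to methoxy and 4-hydroxyphenyl to 4-methoxyphenyl.

Within the data shown here, the expectation rests on compound 3 at > 40000 nM, the only measured compound that carries the 4-hydroxyphenyl group. No change beyond the usual scatter is expected in this assay, and the most likely outcome is another limit rather than a number. The estimated size of the change is a number no higher from compound 3 to compound 4 (the limit leaves the size open). For compound 4 the expected value is 40000 nM, with an estimated range from 25000 nM to 60000 nM.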

Compound 4, half-maximal inhibitory concentration: > 40000 nM
Compound 4 gave a limit, no number; the forecaster's own chance of this, stated with the estimate: 85%; the middle value lies on the limit itself.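

Compound 3 and compound 4 both give a limit rather than a number, so the change from 4-hydroxyphenyl to 4-methoxyphenyl cannot be read as a step: the limit of > 40000 nM in this assay, at which 4 of the 4 values shown sit.

The compounds shown leave open what number any of them would give in this assay, and so whether this methyl in place of hydrogen alters the result at all.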